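The compounds below may be only part of what the source reports. "The series", "measured", "known", "first", "only" and "open" are said of these compounds alone.

Measured so far:
compound 1 `C/C=C/C=C/C(=O)N(Cc1ccc(OC)c(O)c1)c1cc(OC)c(OC)c(OC)c1` — 140 nM
compound 2 `COc1ccc(CN(C(=O)CCCl)c2cc(OC)c(OC)c(OC)c2)cc1O` — 140 nM
compound 3 `COC(=O)c1cc(CNc2cc(OC)c(OC)c(OC)c2)ccc1OC` — 49600 nM

In a functional assay on MGC-803 cells (Homo sapiens) for inhibition, read by MTT assay, with a stated time of 48 h (on this read-out lower numbers stand for stronger inhibition and higher numbers for weaker inhibition), compound 3 stands highest of the three numbers, well beyond the scatter from compound 1 and from compound 2. Among the compounds with values here, the only single-place step, no change at the digits printed from compound 1 to compound 2 (within the scatter), concerns the carbonyl substituent and does not touch the aromatic ring altered here. Compound 4 `COc1ccc(CNc2cc(OC)c(OC)c(OC)c2)cc1F` differs from compound 3 by fluoro in place of methoxycarbonyl on an aromatic carbon, a fluoro in place of methoxycarbonyl on an aromatic carbon. Within the data shown here, no measured pair isolates this exchange, so the expected step of a 1.7-fold lower number from compound 3 to compound 4 (0.22 log units; within the scatter) rests on the gap alone and is set small, with a wide range. Compound 4 is therefore estimated at 30000 nM, between 8000 nM and 120000 nM.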

Compound 4, half-maximal inhibitory concentration: 39700 nM
The estimate for compound 4 lay 1.3-fold (0.12 log units) below the measured number; low and high end bracket the measured number.
By their numbers in this assay, from the lowest: compounds 1 and 2 (each within the scatter of the next); then compounds 4 and 3 (each within the scatter of the next).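

In this assay the exchange of methoxycarbonyl for fluoro, on the aromatic carbon ortho to a methoxy group, gives a 1.2-fold lower number from compound 3 to compound 4 (0.10 log units; within the scatter) and so leaves the reading unchanged within the scatter. At this position, in this pair, going from 4 heavy atoms with 2 hydrogen-bond acceptors to a single fluorine atom gives no readable difference. No evidence at hand bears on this result.

Going by these compounds, whether a carboxylic acid or an amine at this carbon would shift the number remains open. So does whether the same exchange would read alike on the core of compound 1.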